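This account rests on a few compounds, and the source may have more. Where it says the series, first, only, none or still open, it means among the compounds named here.

Working notes on the series. In an ADME assay on microsomes from liver (Mus musculus) for metabolic stability, using NADPH, with a stated time of 10 min (on this read-out lower numbers stand for a less stable compound and higher numbers for a more stable compound), compound 1 `CCCCc1nc(=O)c(S(=O)(=O)c2ccc(-c3cccnc3)cc2)c(O)n1-c1c(OC)cccc1OC` gives 57%. In this assay compound 2 `CCCCc1[nH]c(=O)c(S(=O)(=O)c2ccc(-n3ccccc3=O)cc2)c(O)c1-c1c(OC)cccc1OC` gives 75%, and compound 3 `CCCCc1[nH]c(=O)c(S(=O)(=O)c2ccc(-n3cc(Cl)ccc3=O)cc2)c(O)c1-c1c(OC)cccc1OC` gives 64%. Compound 1 therefore carries the smallest of the three numbers: its gap to compound 3 stays within the usual scatter, while its gap to compound 2 lies beyond it. For the measured compounds named here, the only step between compounds that differ in one place is a number 11 percentage points lower from compound 2 to compound 3 (beyond the scatter), a chloro in place of hydrogen on an aromatic carbon, a change at a different part of the molecule from the one considered here.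

Compound 4 `CCCCc1nc(=O)c(S(=O)(=O)c2ccc(C)cc2)c(O)n1-c1c(OC)cccc1OC` differs from compound 1 by methyl in place of pyridin-3-yl on an aromatic carbon. Going by the values given here, no measured pair covers this exchange, so the one measured step gives no direct guide to it; with nothing to point either way, no step beyond the scatter is expected. Compound 4 is estimated to give about 60% in this assay, with a range from 40% to 80%. For compound 4 the expected change is a number 3 percentage points higher from compound 1 to compound 4 (within the scatter), within the scatter.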

Compound 4, percent of the compound remaining: 80%
For compound 4 the middle estimate is 20 percentage points below the measured one; low and high end bracket the measured number.
By their numbers in this assay, from the lowest: compounds 1 and 3 (each within the scatter of the next); then compounds 2 and 4 (each within the scatter of the next).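

In this assay, the exchange at this aromatic carbon, para to a large group, gives a number 23 percentage points higher from compound 1 to compound 4 (beyond the scatter), so this position clearly bears on the read-out, which the earlier step at a different part of the molecule could not show. Here, methyl, with one heavy atom and no ring, carries the higher number than pyridin-3-yl, with six heavy atoms and an aromatic ring, but a single pair cannot separate the loss of the ring from the loss of its nitrogen. Nothing at hand gives a reason for this step.

From the compounds shown here alone, it remains open whether an unsubstituted phenyl, an ethyl group, a longer alkyl chain or a carboxylic acid at this place would fall nearer compound 1 or compound 4. Going by these compounds, it also remains open whether methyl in place of pyridin-3-yl would give a similar step on the core of compound 2.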